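Phenyl for methyl on a shared core: cytotoxicity notes

A few compounds are considered here, and "the series" means these few. Any claim that something is new, unique, unknown or untested is made for them only; others in the source may bear on it.

Measured in a functional assay on HepG2 cells (Homo sapiens) for cytotoxicity, read by XTT assay, with a stated time of 72 h; on this read-out lower numbers stand for stronger inhibition and higher numbers for weaker inhibition:
compound 1 `CC(=O)N(/N=C/c1ccc(Cl)cc1)c1nc(C)c[se]1` gives 59200 nM.
compound 2 `CC(=O)N(/N=C/c1ccc(Cl)cc1)c1nc(-c2ccccc2)c[se]1` gives > 62000 nM, a limit of the assay.
compound 3 `Cc1c[se]c(NNC(=O)c2ccccc2)n1` gives > 89200 nM, a limit of the assay.

From compound 1 to compound 2 the change is phenyl in place of methyl on an aromatic carbon. The step is an at least 1.0-fold higher number from compound 1 to compound 2 (0.02 log units; that floor lies within the scatter); compound 2 sits at the limit of > 62000 nM in this assay, at which 1 of the 3 values shown sits. Compound 3 differs from compound 1 in more than one place; the difference between the two cores is not broken down here. Compound 3 sits at the limit of > 89200 nM in this assay, at which 1 of the 3 values shown sits.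

Compound 4 `O=C(NNc1nc(-c2ccccc2)c[se]1)c1ccccc1` is still to be measured. It stands to compound 3 as compound 2 stands to compound 1: the change is phenyl in place of methyl on an aromatic carbon, the same change at the same kind of place.

Because the step of an at least 1.0-fold higher number from compound 1 to compound 2 (0.02 log units; that floor lies within the scatter) lies within the scatter, and compound 3 already gives only a limit, compound 4 is expected near 95000 nM, within 45000 nM to 250000 nM, most likely reported as a limit again. That means an expected step that the limit leaves unreadable from compound 3 to compound 4.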

Compound 4, half-maximal inhibitory concentration: > 73000 nM
Compound 4 was reported as a limit; the forecaster's own chance of this, stated with the estimate: 80%; the middle value does not contradict the limit.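

In this assay compound 3 gives > 89200 nM, a limit of the assay. Within the data shown here, compound 4 gives > 73000 nM, also a limit, and no step between these two compounds can be read. The compounds shown leave open whether phenyl in place of methyl on an aromatic carbon changes cytotoxicity at all on either core.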